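The source may hold more compounds than are shown below. What is called first, only, known or untested is meant among the compounds shown, and "the series" means these compounds.

Measured compounds in a physicochemical assay for acid dissociation:

compound 1 `FC(F)(F)c1ccc(-c2ccc3c(NCCCNCc4ccco4)ccnc3c2)cc1`: 9.47
compound 2 `COc1ccc(Oc2ccc3c(NCCCNCc4cccc(OC)c4O)ccnc3c2)cc1`: 9.28
compound 3 `COc1ccc(Oc2ccc3c(NCCCNCc4ccco4)ccnc3c2)cc1`: 9.28

Compound 2 stands level with compound 3 at the digits shown, the two together the lowest of the three numbers. Compound 1 is the furthest from compound 2, yet its value differs from that of compound 2 only within the scatter, so no order among the three can be read from these numbers.

Compound 4 `COc1cccc(CNCCCNc2ccnc3cc(-c4ccc(C(F)(F)F)cc4)ccc23)c1O` is the unmeasured member. It differs from compound 2 at one place: 4-(trifluoromethyl)phenyl in place of 4-methoxyphenoxy on an aromatic carbon. Going by the values given here, one measured step bears on this directly: a number 0.19 log units lower from compound 1 to compound 3 (within the scatter), which is the same exchange on the same position of the shared core, run in the opposite direction. A second step, no change at the digits printed from compound 2 to compound 3 (within the scatter), shows that the other variable part of the series leaves this assay untouched, so the behaviour seen between compound 1 and compound 3 should carry over to compound 2 and compound 4. The step of a number 0.19 log units higher from compound 2 to compound 4 (within the scatter) is therefore expected to be small, upward if anything, and within the scatter. Compound 4 is estimated at 9.47, with a range from 9.15 to 9.8.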

Compound 4, acid dissociation constant: 9.47
Compound 4: the middle estimate sits on the measured number at the digits printed; measured number inside the range.
By their numbers in this assay, from the lowest: compounds 2, 3, 1 and 4 (each within the scatter of the next).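

With both side groups now varied, the exchange of 4-methoxyphenoxy for 4-(trifluoromethyl)phenyl on the aromatic carbon can be read in this assay against a second partner, 2-hydroxy-3-methoxyphenyl, and it gives a number 0.19 log units higher from compound 2 to compound 4 (within the scatter), the same size as the reverse exchange with furan-2-yl, a number 0.19 log units lower from compound 1 to compound 3 (within the scatter). The exchange on the saturated chain carbon, so far read only with 4-methoxyphenoxy on the aromatic carbon, can now be read with 4-(trifluoromethyl)phenyl there, and it gives no change at the digits printed from compound 1 to compound 4 (within the scatter), so neither change takes this read-out beyond the scatter in either setting, and the effect of each shows no dependence on the other at the digits printed. No measurement at hand accounts for these numbers.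

Going by these compounds, it remains open whether the aromatic carbon stays this unresponsive with a group of another kind, such as an amine or a carboxylic acid. On these data alone, it is equally open whether a longer chain in the shared core, or a nitrile on the ring of the chain end, would move the number in this assay beyond the scatter.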